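A few compounds are considered here, and "the series" means these few. Any claim that something is new, unique, unknown or untested is made for them only; others in the source may bear on it.

In an assay on HEK293 cells for inhibition of N-acylethanolamine-hydrolyzing acid amidase (Rattus norvegicus), read by LC-MS, with a stated time of 30 min (on this read-out higher numbers stand for weaker inhibition and lower numbers for stronger inhibition), the three measured compounds stand as follows:

compound 1, `O=C(CCCCCc1cccc(Br)c1)N1CCOC1=O`: 430 nM
compound 2, `O=C(CCCCCc1ccc(O)cc1)N1CCOC1=O`: 61 nM
compound 3, `O=C(CCCCCc1ccc(CO)cc1)N1CCOC1=O`: 190 nM

Compound 1 gives the highest of the three numbers, that is the weakest inhibition recorded so far in this assay; compound 3 comes nearest to it and compound 2 lies furthest away, both beyond the scatter. Among the measured compounds shown here, the one single-point step available is a 3.1-fold higher number from compound 2 to compound 3 (0.49 log units; beyond the scatter); it concerns a change from hydroxy to hydroxymethyl on an aromatic carbon of the shared core and so does not touch the group that is changed here.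

Compound 4, `O=C(CCCCCc1cccc(C(F)(F)F)c1)N1CCOC1=O`, differs from compound 1 by trifluoromethyl in place of bromo on an aromatic carbon. For the measured compounds named here, no measured pair covers a halogen-to-trifluoromethyl swap, so there is nothing in the data that sets a direction for this step in this assay. Given that, the expectation is a number close to that of compound 1, with any shift most likely within or only just beyond the scatter, which is what a 1.2-fold higher number from compound 1 to compound 4 (0.07 log units; within the scatter) means. The estimate for compound 4 in this assay is therefore 500 nM, with a range from 200 nM to 1300 nM, to be compared with the measurement once it is in hand.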

Compound 4, half-maximal inhibitory concentration: 58 nM
Estimate against measurement, compound 4: 8.6-fold (0.94 log units) above; the measured number lies below the stated range.
By their numbers in this assay, from the lowest: compounds 4 and 2 (each within the scatter of the next); then compound 3; then compound 1.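

In this assay the change at this aromatic carbon, meta to a large group, gives a 7.4-fold lower number from compound 1 to compound 4 (0.87 log units; beyond the scatter) and so shows that the position responds to the group it carries, which the earlier step, a change from hydroxy to hydroxymethyl, could not show. Neither bromo nor trifluoromethyl has a hydrogen-bond donor or acceptor or a net charge, so this step occurs with those counts unchanged and the difference in the counts lies only in heavy atoms. Nothing available here accounts for the size or direction of this step.

On these data alone, whether chloro, a nitrile or a methoxy group on this same carbon would give a number nearer to that of compound 1 or to that of compound 4 remains open. Also open, as far as these compounds go, is whether the swap from bromo to trifluoromethyl would give a step of similar size on a compound with a longer or shorter chain joining the aromatic ring to the shared core.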